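The compounds below may be only part of what the source reports. "The series", "measured", "known", "first", "only" and "open" are said of these compounds alone.

Values in a functional assay on KG-1 cells (Homo sapiens) for cytotoxicity, read by luminescence and CellTiter-Glo, with a stated time of 3 days (a lower number here means a stronger inhibitor, a higher number a weaker inhibitor), for the compounds measured so far

compound 1 `N#Cc1ccc(NC(=O)c2ccc3ccccc3c2O)cc1` gives 2720 nM
compound 2 `N#Cc1ccc(NC(=O)c2ccc(C(F)(F)F)cc2O)cc1` gives 1440 nM
compound 3 `COc1ccc(C(=O)Nc2ccc(C#N)cc2)c(O)c1` gives 5430 nM

Compound 3 lies within the usual scatter of compound 1, so those two cannot be told apart. It lies beyond the scatter of compound 2, whose number is the lower of that pair.

The compound still to be measured is compound 4 `N#Cc1ccc(NC(=O)c2ccc(Br)cc2O)cc1` and it differs from compound 3 in a single place (bromo in place of methoxy on an aromatic carbon). The change is bromo in place of methoxy on an aromatic carbon, meta to a hydroxy group and para to a large group.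

Among the compounds with values here, only one measured step touches that same carbon. The step of a 3.8-fold higher number from compound 2 to compound 3 (0.58 log units; beyond the scatter) shows what happened when methoxy took the place of trifluoromethyl. Read backwards, it suggests that losing methoxy may lower the number. Within the data shown here, no compound with bromo has been measured yet, so this single step is thin support, and only part of that change is expected to carry over.

The expected result is a 2.5-fold lower number from compound 3 to compound 4 (0.39 log units; beyond the scatter) in this assay as a modest move toward a stronger inhibitor. For compound 4 the estimated value is 2200 nM with an expected range from 1100 nM to 4500 nM in this measurement.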

Compound 4, half-maximal inhibitory concentration: 1450 nM
Estimate against measurement, compound 4: 1.5-fold (0.18 log units) above, within the range that was stated.
By their numbers in this assay, from the lowest: compounds 2, 4, 1 and 3 (each within the scatter of the next, the first and the last beyond it).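

Measured in this assay on the same aromatic carbon, bromo in place of methoxy gives a 3.7-fold lower number from compound 3 to compound 4 (0.57 log units; beyond the scatter) and so the earlier step from trifluoromethyl to methoxy now has a counterpart: a second, quite different group also stands apart from methoxy. Bromo in place of trifluoromethyl gives a 1.0-fold higher number from compound 2 to compound 4 (0.00 log units; within the scatter) and so these two groups cannot be told apart here, even though bromo is a single bromine atom and trifluoromethyl is built from carbon and fluorine. Among the three groups seen on this carbon, methoxy alone has the higher number, something the one earlier step could not show, since a comparison of only two groups cannot reveal which of them is the odd one out.

Nothing shown gives a measured reason why methoxy differs from bromo and trifluoromethyl. The compounds shown also leave open how an amine, a carboxylic acid or a longer chain such as ethoxy would behave on this carbon, and whether a plain hydrogen there would match methoxy or the other two groups.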